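A few compounds are considered here, and "the series" means these few. Any claim that something is new, unique, unknown or untested is made for them only; others in the source may bear on it.

Measured in a functional assay on HepG2 cells (Homo sapiens) for inhibition, read by MTT assay, with a stated time of 48 h; a lower number here means a stronger inhibitor, a higher number a weaker inhibitor:
- compound 1 `COc1cc(-c2nccn3cc(-c4ccc5[nH]ccc5c4)nc23)cc(OC)c1OC`: 146 nM
- compound 2 `COc1cc(-c2nccn3cc(-c4ccccc4)nc23)cc(OC)c1OC`: 267 nM
- compound 3 `COc1cc(-c2nccn3cc(-c4ccc(N)cc4)nc23)cc(OC)c1OC`: 252 nM

Compound 3 has the second highest of the three numbers, but all three lie within the scatter of one another. Compound 4 `COc1cc(-c2nccn3cc(-c4ccc(C)cc4)nc23)cc(OC)c1OC` carries methyl in place of amino on an aromatic carbon, para to a large group: methyl in place of amino on an aromatic carbon. Going by the values given here, no measured step makes this exchange directly. The closest evidence is a 1.1-fold lower number from compound 2 to compound 3 (0.03 log units; within the scatter), at the same place, while a 1.8-fold higher number from compound 1 to compound 2 (0.26 log units; within the scatter) and a 1.7-fold higher number from compound 1 to compound 3 (0.24 log units; within the scatter) are also small. No step beyond the scatter is therefore expected in this assay, and no direction is favoured. The expected change is a 1.1-fold lower number from compound 3 to compound 4 (0.02 log units; within the scatter). Compound 4 is estimated at 240 nM, with an expected range of 120 nM to 480 nM.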

Compound 4, half-maximal inhibitory concentration: 160 nM
Compound 4: middle estimate off by 1.5-fold (0.18 log units), on the high side; low and high end bracket the measured number.
By their numbers in this assay, from the lowest: compounds 1, 4, 3 and 2 (each within the scatter of the next).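

At this place, para to a large group, three substituents now sit within the scatter of one another in this assay: a 1.6-fold lower number from compound 3 to compound 4 (0.20 log units; within the scatter), and a 1.7-fold lower number from compound 2 to compound 4 (0.22 log units; within the scatter). Methyl, with 0 hydrogen-bond donors, therefore reads no differently from amino or hydrogen here, and the exchange of 4-methylphenyl for 1H-indol-5-yl is equally unresolved, with a 1.1-fold higher number from compound 1 to compound 4 (0.04 log units; within the scatter). No measurement is available that bears on these small steps.

Open, on these data alone, is whether any group at this place, such as a carboxylic acid or a longer chain, gives a step beyond the scatter.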